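A Larger Side Arm on the Shared Core

The source may hold more compounds than are shown below. What is called first, only, known or untested is meant among the compounds shown, and "the series" means these compounds.

Compound 1 `COc1ccc(-c2nc(/N=C(\N)NC(C)C)sc2-c2ccc(OC)cc2)cc1`: 9.1 uM
Compound 2 `COc1ccc(-c2nc(CN(C)C)sc2-c2ccc(OC)cc2)cc1`: 8.4 uM

Of the compounds shown here, two have been measured in a functional assay (aorta) with Rattus norvegicus as the target; a higher number here means that more compound is needed for the effect, a lower number that less compound is needed. Compound 1 `COc1ccc(-c2nc(/N=C(\N)NC(C)C)sc2-c2ccc(OC)cc2)cc1` gives 9.1 uM, and compound 2 `COc1ccc(-c2nc(CN(C)C)sc2-c2ccc(OC)cc2)cc1` gives 8.4 uM. Going by the values given here, compound 2 holds the lowest of the two numbers, but its only neighbour, compound 1, lies within the scatter, so no order can be read between them. Among the compounds with values here, the single measured step, a 1.1-fold lower number from compound 1 to compound 2 (0.03 log units; within the scatter), exchanged one group for another on an aromatic carbon without moving the number.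

Compound 3 `CCOC(=O)/C(C#N)=C/c1nc(-c2ccc(OC)cc2)c(-c2ccc(OC)cc2)s1` differs from compound 2 by 2-cyano-2-(ethoxycarbonyl)ethenyl in place of (dimethylamino)methyl on an aromatic carbon. The group that enters is larger than either group compared in the earlier step, and it sits at the same place. Because a 1.1-fold lower number from compound 1 to compound 2 (0.03 log units; within the scatter) lay within the scatter, the expected change is a 1.2-fold higher number from compound 2 to compound 3 (0.08 log units; within the scatter), with the range widened for the unfamiliar group. The expected value for compound 3 is 10 uM, between 3 uM and 35 uM.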

Compound 3, concentration for half-maximal effect: > 100 uM
Compound 3 gave a limit, no number (the forecaster's own chance of this, stated with the estimate: 15%); at least 10-fold (1.00 log units) between middle value and limit.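

The earlier exchange left the number unmoved, but this position on an aromatic carbon is not indifferent to the group it carries: in this assay, 2-cyano-2-(ethoxycarbonyl)ethenyl in place of (dimethylamino)methyl gives an at least 11-fold higher number from compound 2 to compound 3 (1.07 log units; beyond the scatter). Set against the other group measured at this place, the entering group gives a rise of the same order, an at least 10-fold higher number from compound 1 to compound 3 (1.04 log units; beyond the scatter). The value of compound 3 is a limit of the assay and not a number: the limit of > 100 uM in this assay, at which 1 of the 3 values shown sits.

The ethyl ester, the nitrile and the double bond enter together, so the compounds shown do not tell which of them goes with the rise, or how far it extends. From the compounds shown here alone, it also remains open whether a carboxylic acid, a primary amide or a longer chain ending in an amine at this position would keep the number or raise it.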